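A few compounds are considered here, and "the series" means these few. Any claim that something is new, unique, unknown or untested is made for them only; others in the source may bear on it.

Measured in a functional assay on SW-620 cells (Homo sapiens) for cytotoxicity; a higher number here means a weaker inhibitor of growth, a lower number a stronger inhibitor of growth:

Compound 1 `COc1ccc(C2=C(c3ccc(SC)cc3)CC3CCCN3C2=O)cc1C`: 500 nM
Compound 2 `CSc1ccc(C2=C(c3ccc(C)c(C)c3)C(=O)N3CCCC3C2)cc1`: 700 nM
Compound 3 `COc1ccc(C2=C(c3ccc(SC)cc3)CC3CCCN3C2=O)cc1`: 3000 nM

Compound 3, at 3000 nM, has the highest number of the three and is therefore the weakest inhibitor of growth so far. Its gaps to the other two lie beyond the scatter, while the gap between those two does not: a 1.4-fold higher number from compound 1 to compound 2 (0.15 log units; within the scatter).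

Compound 4 `CSc1ccc(C2=C(c3ccc(OCC4CO4)cc3)C(=O)N3CCCC3C2)cc1` starts from compound 3 and makes one change: oxiran-2-yl in place of hydrogen on a saturated chain carbon bound to an oxygen on an aromatic ring. In words, oxiran-2-yl stands in place of hydrogen on a saturated chain carbon bound to an oxygen on an aromatic ring, so methoxy becomes (oxiran-2-yl)methoxy.

Among the compounds with values here, no measured step makes this change. The nearest evidence comes from two steps that alter the same aromatic ring: a 6.0-fold higher number from compound 1 to compound 3 (0.78 log units; beyond the scatter) and a 4.3-fold higher number from compound 2 to compound 3 (0.63 log units; beyond the scatter). Both are modest, and both show that compound 3 can be improved upon by changes on this ring. They suggest a step of similar modest size, leaning towards a lower number, but the direction is uncertain.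

The estimated step is a 2.5-fold lower number from compound 3 to compound 4 (0.40 log units; beyond the scatter). Compound 4 is expected at about 1200 nM, with an estimated range from 300 nM to 5000 nM.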

Compound 4, concentration for 50% growth inhibition: 90 nM
Estimate against measurement, compound 4: 13-fold (1.12 log units) above, and the stated range ends above it.
By their numbers in this assay, from the lowest: compound 4; then compounds 1 and 2 (each within the scatter of the next); then compound 3.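

In this assay, placing oxiran-2-yl on the saturated chain carbon bound to an oxygen on an aromatic ring gives a 33-fold lower number from compound 3 to compound 4 (1.52 log units; beyond the scatter), the only large step among these compounds. The earlier steps shown here on this ring exchanged methyl, methoxy and hydrogen on aromatic carbons, whereas this one shows that the methoxy group can be extended outward from its own carbon, turning it into (oxiran-2-yl)methoxy, and that this extension goes with a much lower number. Nothing measured here accounts for the size of this step.

The compounds shown leave open whether the three-membered ring with its oxygen matters or whether other groups on that carbon would give a similar step, such as a plain ethyl or propyl chain, a cyclopropyl ring, or a chain ending in a hydroxyl group or an amine. They also leave open whether (oxiran-2-yl)methoxy would give a step of similar size with the extra methyl of compound 1 on the same ring.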